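The compounds below may be only part of what the source reports. "The series", "measured", "known", "first", "only" and "open" are said of these compounds alone.

For the measured compounds named here, compound 2 `CNc1nc(-n2cc(CC3CCCC3)nn2)nc2c1ncn2[C@@H]1O[C@H](CO)[C@@H](O)[C@H]1O` gives 1.3 nM in an assay on CHO cells for displacement of a labelled ligand from adenosine receptor A3 (Homo sapiens) (on this read-out lower numbers stand for stronger inhibition and higher numbers for weaker inhibition), the lower of the two numbers so far; compound 1 `CCc1cn(-c2nc(NC)c3ncn([C@@H]4O[C@H](CO)[C@@H](O)[C@H]4O)c3n2)nn1` gives 13.8 nM, and the change from compound 1 to compound 2 brought an 11-fold lower number from compound 1 to compound 2 (1.03 log units; beyond the scatter). Compound 3 `CNc1nc(-n2cc(Cc3ccccc3)nn2)nc2c1ncn2[C@@H]1O[C@H](CO)[C@@H](O)[C@H]1O` differs from compound 2 by phenyl in place of cyclopentyl on a saturated chain carbon bound to an aromatic carbon. Going by the values given here, the one measured step at this position concerns growth from methyl to cyclopentyl, not exchange of one large group for another, so no measured step bears directly on it; a step of a 1.5-fold higher number from compound 2 to compound 3 (0.19 log units; within the scatter) is expected, not beyond the scatter. For compound 3 the estimate in this assay is 2 nM, with a range of 0.5 nM to 8 nM.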

Compound 3, inhibition constant: 9.5 nM
The estimate for compound 3 lay 4.8-fold (0.68 log units) below the measured number; the measured number lies above the stated range.
By their numbers in this assay, from the lowest: compound 2; then compounds 3 and 1 (each within the scatter of the next).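

In this assay phenyl in place of cyclopentyl brings a 7.3-fold higher number from compound 2 to compound 3 (0.86 log units; beyond the scatter) and so gives up most of the gain seen with cyclopentyl. Phenyl in place of methyl brings only a 1.5-fold lower number from compound 1 to compound 3 (0.16 log units; within the scatter) and shows that, among these compounds, a ring on this carbon does not by itself bring the gain. Nothing at hand explains the difference between the two rings. Open, on these data alone, is whether cyclohexyl or a longer chain on this carbon stands with cyclopentyl or with phenyl. Also open, as far as these compounds go, is whether an amine on the phenyl ring alters the result.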